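Ester variation on the chlorophenyl piperidine core

The source may hold more compounds than are shown below. What is called first, only, known or untested is meant among the compounds shown, and "the series" means these compounds.

Going by the values given here, three esters on the shared core have numbers so far. In an assay on Cortex with Norepinephrine transporter (Rattus norvegicus) as the target (on this read-out lower numbers stand for stronger inhibition and higher numbers for weaker inhibition), compound 1 `CN1CC[C@H](c2ccc(Cl)cc2)[C@@H](C(=O)OC(C)(C)C)C1` gives 350 nM, the lowest of the three. Compound 2 `CN1CC[C@H](c2ccc(Cl)cc2)[C@@H](C(=O)OCCCCCc2ccccc2)C1` gives 382 nM in this assay, and this lies within the scatter of compound 1, so the two are not distinguished. Compound 3 `CN1CC[C@H](c2ccc(Cl)cc2)C(C(=O)Oc2ccccc2)C1` gives 2180 nM in this assay, a number that stands beyond the scatter from compound 1; this compound also carries no defined stereochemistry on the ester-bearing ring carbon.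

Compound 4 `CCOC(=O)C[C@H]1CN(C)CC[C@@H]1c1ccc(Cl)cc1` has not been measured. It differs from compound 1 by (ethoxycarbonyl)methyl in place of tert-butoxycarbonyl on a saturated ring carbon. Among the compounds with values here, no measured pair shows this change, and the two alkyl esters compound 1 and compound 2 give no lead on it, since their numbers sit within the scatter of each other. A step toward a somewhat higher number is expected, of a size that may or may not exceed the scatter, as a 1.9-fold higher number from compound 1 to compound 4 (0.27 log units; within the scatter). Compound 4 is therefore estimated at 650 nM in this assay, with a range from 220 nM to 2000 nM.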

Compound 4, inhibition constant: 101 nM
The estimate for compound 4 lay 6.4-fold (0.81 log units) above the measured number; measured number below the stated range.
By their numbers in this assay, from the lowest: compound 4; then compounds 1 and 2 (each within the scatter of the next); then compound 3.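

In this assay, going by these compounds alone, (ethoxycarbonyl)methyl in place of tert-butoxycarbonyl on a saturated ring carbon gives a 3.5-fold lower number from compound 1 to compound 4 (0.54 log units; beyond the scatter), the one step in hand between measured compounds that differ in one place. A carbonyl attached directly to this ring carbon is therefore not required for a number at this level, although the ester alkyl part and its attachment to the ring change together, so the step belongs to neither alone. Nothing in hand accounts for the step.

Open, as far as these compounds go, is whether the lower number follows the added methylene or the ethyl ester; an ethyl ester on the ring carbon itself or a (tert-butoxycarbonyl)methyl group would separate the two. Also open, from the compounds shown here alone, is how a carboxylic acid, or a longer chain carrying the ester, reads in this assay at this position.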